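The source may report more compounds than this note shows. Statements on the series, on what has been measured and on what is new or still open speak of the compounds shown alone.

Measured so far in an in vitro functional assay on cells for agonist activity at Bombesin receptor subtype-3 (Mus musculus), read by luminescence and calcium flux; a lower number here means that less compound is needed, a higher number that more compound is needed for the effect:
- compound 1 `CCCCc1cnc(CCc2ccc(-c3ccccc3C(=O)O)cc2)[nH]1` gives 93 nM
- compound 2 `N#Cc1cccc(Cc2cnc(CCc3ccc(-c4ccccc4C(=O)O)cc3)[nH]2)c1` gives 20 nM
- compound 3 `CCCCc1cnc(C(CCC)Cc2ccc(-c3ccccc3C(=O)O)cc2)[nH]1` gives 165 nM

Compound 2 has the lowest number of the three in this assay; the nearest is compound 1, and the furthest is compound 3, with both gaps beyond the scatter. The steps seen so far are a 4.7-fold lower number from compound 1 to compound 2 (0.67 log units; beyond the scatter) and a 1.8-fold higher number from compound 1 to compound 3 (0.25 log units; within the scatter); only the first concerns the position on the saturated chain carbon that is varied next.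

Compound 4 `O=C(O)c1ccccc1-c1ccc(CCc2ncc(Cc3ccccc3)[nH]2)cc1` is not yet measured. Relative to compound 2 the change is hydrogen in place of cyano on an aromatic carbon; compound 4 therefore carries a benzyl group where compound 2 carries 3-cyanobenzyl, and sits structurally between compound 1 and compound 2. Within the data shown here, no measured step removes a cyano group alone, so the size of its contribution is unknown. The step from compound 1 to compound 2 shows that the whole 3-cyanophenyl group in place of propyl is worth a modest improvement; part of that gain may rest on the cyano group, so a modest move back toward the number of compound 1 is expected, as a 2.5-fold higher number from compound 2 to compound 4 (0.40 log units; beyond the scatter). For compound 4 the estimate in this assay is 50 nM, with a likely range from 20 nM to 130 nM.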

Compound 4, half-maximal effective concentration: 11 nM
Compound 4: middle estimate off by 4.5-fold (0.66 log units), on the high side; measured number below the stated range.
By their numbers in this assay, from the lowest: compounds 4 and 2 (each within the scatter of the next); then compounds 1 and 3 (each within the scatter of the next).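

In this assay the step of a 1.8-fold lower number from compound 2 to compound 4 (0.26 log units; within the scatter) lies within the scatter, so on this aromatic carbon of the six-membered ring, hydrogen and cyano cannot be told apart, and the nitrile is not required for a number at this level. The step of an 8.5-fold lower number from compound 1 to compound 4 (0.93 log units; beyond the scatter) lies beyond the scatter and shows that phenyl in place of propyl, without any cyano group, is enough for a lower number than that of compound 1; the earlier step of a 4.7-fold lower number from compound 1 to compound 2 (0.67 log units; beyond the scatter) could not separate the phenyl from its nitrile. Nothing at hand explains either step.

Going by these compounds, whether chlorine, a methoxy group or an amine in place of this hydrogen would also leave the number within the scatter of compound 4 stays open, as does the outcome for a phenethyl or cyclohexylmethyl group in place of benzyl. Among these compounds, it is also open whether propyl on the saturated chain carbon, seen only in compound 3, would give a similar result alongside benzyl or 3-cyanobenzyl.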